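A few compounds are considered here, and "the series" means these few. Any claim that something is new, unique, unknown or untested is made for them only; others in the source may bear on it.

The series shares one core, first seen in compound 1 `COC(=O)c1cc(=O)c2c(OC)cc(OC)cc2n1C` and then in compound 2 `COC(=O)c1cc(=O)c2c(OC)cc(OC)cc2n1S(=O)(=O)c1ccc(C)cc1`. In a functional assay on SUP-B15 cells (Homo sapiens) for antiproliferative activity, with a stated time of 72 h (a lower number here means that less compound is needed, a higher number that more compound is needed for the effect), compound 1 reaches only a limit of the assay, > 37900 nM. Compound 2, by contrast, gives a measured value in this assay of 9700 nM. Compound 3 `COc1ccc(-c2cc(=O)c3c(OC)cc(OC)cc3n2S(=O)(=O)c2cccc([N+](=O)[O-])c2)cc1` carries a 3-nitrophenyl on the sulfonyl sulfur, and in this assay compound 3 again returns only a limit, > 39600 nM, so that its standing among the three values rests on the ceiling of the assay alone (the limit of > 39600 nM in this assay, at which 1 of the 3 values shown sits); a second limit of the same kind is that of compound 1 (the limit of > 37900 nM in this assay, at which 1 of the 3 values shown sits). Compound 4 `COc1ccc(-c2cc(=O)c3c(OC)cc(OC)cc3n2S(=O)(=O)c2cc(F)c(F)c(F)c2)cc1` is not yet measured. It differs from compound 3 in one place: 3,4,5-trifluorophenyl in place of 3-nitrophenyl on a sulfonyl sulfur. Within the data shown here, no measured step frames this change, and nothing among the known values points to a direction beyond the scatter. The step from compound 3 to compound 4 is therefore expected to be small, an at least 1.3-fold lower number from compound 3 to compound 4 (0.12 log units; that floor lies within the scatter). Compound 4 is estimated at 30000 nM in this assay, within a range from 8000 nM to 80000 nM, with a fair chance that only a limit is reported.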

Compound 4, half-maximal effective concentration: > 65500 nM
Compound 4: only a limit was reported; the forecaster's own chance of this, stated with the estimate: 55%; at least 2.1-fold (0.33 log units) between middle value and limit.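

In this assay compound 4 gives only a limit, > 65500 nM. Among these compounds, compound 3 also stands at a limit, so no step between compound 3 and compound 4 can be read. The compounds shown leave open how either sulfonyl substituent would compare in this assay as a measured value.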